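This account rests on a few compounds, and the source may have more. Where it says the series, first, only, none or still open, it means among the compounds named here.

Of the compounds shown here, two have been measured so far in a functional assay for inhibition of metabotropic glutamate receptor 2 (Homo sapiens); on this read-out higher numbers stand for weaker inhibition and lower numbers for stronger inhibition. Compound 1, `CCC(N)(C(=O)O)[C@H]1C[C@@H]1C(=O)O`, gives 6500 nM in this assay. Compound 2, `CC(C)C[C@](N)(C(=O)O)C1C[C@@H]1C(=O)O`, gives 1600 nM in this assay, the lowest of the two numbers, and the gap to compound 1 lies beyond the usual scatter of such measurements. Compound 3, `N[C@@](CC1CCC1)(C(=O)O)C1C[C@@H]1C(=O)O`, shares the same core with compound 2 and differs from it in one place: cyclobutyl in place of isopropyl on a saturated chain carbon, two bonds along the chain from an amine nitrogen, a carbonyl carbon and a saturated ring carbon. Among the measured compounds shown here, no other pair in this set shows this particular change, so there is no measured step to lean on. For the measured compounds named here, the two values so far show only that compound 2, which carries the longer branched side chain, stands lower than compound 1. On that basis a modest step is expected, toward a somewhat lower number, with a size of a 1.6-fold lower number from compound 2 to compound 3 (0.20 log units; within the scatter) that could also fall within the scatter. Compound 3 is therefore estimated at 1000 nM in this assay, within a range from 400 nM to 3000 nM.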

Compound 3, half-maximal inhibitory concentration: > 10000 nM
Compound 3: no number, only a limit; the forecaster's own chance of this, stated with the estimate: 5%; at least 10-fold (1.00 log units) between middle value and limit.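

In this assay compound 3 gives only a limit of the assay, not a number: the limit of > 10000 nM in this assay, at which 1 of the 3 values shown sits. Even so, the swap of isopropyl for cyclobutyl gives an at least 6.2-fold higher number from compound 2 to compound 3 (0.79 log units; beyond the scatter), the first step in this set where a single change can be read on its own. It shows that this place on the side chain, two bonds along the chain from an amine nitrogen, a carbonyl carbon and a saturated ring carbon, does not accept every small carbon group equally: going from 3 carbon atoms without a ring to 4 carbon atoms in a ring is enough to weaken inhibition clearly.

As far as these compounds go, how far compound 3 lies past its limit stays unknown. Also open, from the compounds shown here alone, is whether the ring or the added carbon matters, which a cyclopropyl group or an open butyl chain at this place could help to separate.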